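The source may report more compounds than this note shows. Statements on the series, on what has been measured and on what is new or still open speak of the compounds shown alone.

Values in a functional assay on RAW264.7 cells (Mus musculus), read by immunoassay, with a stated time of 24 h (on this read-out lower numbers stand for stronger inhibition and higher numbers for weaker inhibition), for the two measured compounds:

- compound 1, `Cc1ccc(OC(=O)N(Nc2ccccc2)S(=O)(=O)c2ccccc2)cc1`: 1020 nM
- compound 2, `Cc1ccc(S(=O)(=O)N(Nc2ccccc2)C(=O)Oc2ccccc2)cc1`: 5720 nM

Among these two numbers, compound 2 stands at the top: its value in this assay is the higher one, and the only comparison available, with compound 1, shows compound 1 sitting well below it, by a gap beyond the usual scatter. The two compounds differ from each other in more than one place, so that gap cannot be pinned on any single change.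

The next compound, compound 3, `COc1ccccc1OC(=O)N(Nc1ccccc1)S(=O)(=O)c1ccc(C)cc1`, is built from compound 2 by one alteration: methoxy in place of hydrogen on an aromatic carbon. Among the measured compounds shown here, no measured pair in this set isolates this particular change, so there is nothing in the numbers to say which way it will pull. Without such a reference, the step from compound 2 to compound 3 in this assay is expected to be small, a 1.3-fold lower number from compound 2 to compound 3 (0.10 log units; within the scatter), most likely none beyond the scatter in either direction. On that basis compound 3 is estimated at 4500 nM in this assay, with a range from 1500 nM to 14000 nM.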

Compound 3, half-maximal inhibitory concentration: 34.1 nM
Beside the measured number, compound 3's estimate is 130-fold (2.12 log units) above it; the whole stated range lies above it.
By their numbers in this assay, from the lowest: compound 3; then compound 1; then compound 2.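

In this assay, swapping one hydrogen for methoxy, which turns phenoxy into 2-methoxyphenoxy, brings a 170-fold lower number from compound 2 to compound 3 (2.22 log units; beyond the scatter), a large step far beyond the scatter. The earlier compounds shown here could not show this, since they differ in more than one place, whereas this pair shows that a spot on an aromatic carbon, ortho to a large group, can strongly change the read-out when only 2 heavy atoms are added. Nothing available explains why so small an addition has so large an effect on inhibition in these cells.

The compounds shown leave open whether the gain belongs to methoxy itself or would also come with another group at the same place, such as hydroxyl, ethoxy or a chlorine atom, and whether methoxy would have the same effect elsewhere on that ring. Among the compounds shown here, with only one pair isolating this change, it also remains open whether adding methoxy in the same way to a compound with a different arrangement of the other groups, such as compound 1, would bring a step of similar size.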